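The source may report more compounds than this note shows. Statements on the series, on what has been measured and on what is new or still open speak of the compounds shown alone.

Measured so far in a functional assay on the whole organism for inhibition, with Rattus norvegicus as the target, read by paw edema, with a stated time of 4 h, at a dose of 50 mg/kg; on this read-out higher numbers stand for more inhibition at the one dose given (going by the name of the read-out) and lower numbers for less inhibition:
- compound 1, `CC(=O)c1c(NNc2ccccc2)cc(C)oc1=O`: 52%
- compound 2, `CC(=O)c1c(NNc2cc(C)c3ccccc3n2)cc(C)oc1=O`: 51%
- compound 3, `Cc1ccc(-n2nc3cc(C)oc(=O)c3c2C)cc1`: 41.7%

Compound 3 stands lowest of the three numbers in this assay. Its gap to compound 1 is beyond the usual scatter, so compound 1 reads as the more inhibiting of that pair. Its gap to compound 2 lies within the scatter, and nothing is said about the order of compound 2 and compound 3. Going by the values given here, compound 1 and compound 2 share a core that differs from that of compound 3, so no single-change step connects any two of the measured compounds.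

Compound 4, `COc1ccc(-n2nc3cc(C)oc(=O)c3c2C)cc1`, is not yet measured in this assay. It differs from compound 3 by one change: methoxy in place of methyl on an aromatic carbon, on an aromatic carbon of a six-membered aromatic ring of carbon only, para to a large group. Among the compounds with values here, no measured pair shows what this exchange does on this core, so the expectation rests on compound 3 alone, at 41.7%.

With nothing to point in either direction, the step is expected to be none beyond the scatter, a number 0.3 percentage points higher from compound 3 to compound 4 (within the scatter). Compound 4 is therefore estimated at 42%, with a range from 28% to 56%.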

Compound 4, a percentage reported as inhibition, in the whole organism at one dose (the size of the read-out at that dose, not a potency): 42.2%
Compound 4: middle estimate off by 0.2 percentage points, on the low side; measured number inside the range.
By their numbers in this assay, from the lowest: compounds 3, 4, 2 and 1 (each within the scatter of the next, the first and the last beyond it).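

Going by these compounds alone, this is the first step that can be read across a single change: in this assay, methoxy in place of methyl on an aromatic carbon, para to a large group, gives a number 0.5 percentage points higher from compound 3 to compound 4 (within the scatter). On this core, the exchange therefore does not separate the two compounds at the one dose and time given, even though the entering group has more heavy atoms and brings a hydrogen-bond acceptor that methyl lacks. Nothing at hand bears on the reason for this result.

The pair leaves open whether the response at this place stays flat for groups of other kinds, such as a chlorine atom, a trifluoromethyl group, an amine, a carboxylic acid or a longer alkoxy chain, since one exchange cannot be extended to them. Within the data shown here, it also leaves open whether the same exchange would behave in the same way at another place on the aromatic ring, and no single-change step yet links this core to the core of compound 1.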